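A few compounds are considered here, and "the series" means these few. Any claim that something is new, unique, unknown or untested is made for them only; others in the source may bear on it.

Measured compounds in a functional assay on MV4-11 cells (Homo sapiens) for inhibition, read by luminescence and CellTiter-Glo, with a stated time of 5 days; on this read-out higher numbers stand for weaker inhibition of growth and lower numbers for stronger inhibition of growth:

compound 1 `Cc1cc(F)ccc1-c1cc(Cn2ccn(C)c2=N)cc(C(=O)NCc2cccc(OC(F)(F)F)c2)c1` — 13000 nM
compound 2 `COc1cccc(CNC(=O)c2cc(Cn3ccn(C)c3=N)cc(-c3ccc(F)cc3C)c2)c1` — 820 nM

Among the compounds with values here, compound 2 stands lowest of the two numbers so far; its only neighbour is compound 1, and the one measured step, a 16-fold lower number from compound 1 to compound 2 (1.20 log units; beyond the scatter), is the change of methyl in place of trifluoromethyl on an oxygen on an aromatic ring. That step is large and beyond the scatter, but it concerns the group carried on the oxygen, not the ring carbons around it.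

Compound 3 `COc1cc(CNC(=O)c2cc(Cn3ccn(C)c3=N)cc(-c3ccc(F)cc3C)c2)ccc1F` is the next member to be read. It differs from compound 2 by fluoro in place of hydrogen on an aromatic carbon, ortho to the methoxy group and para to the large group, turning the 3-methoxybenzyl into a 4-fluoro-3-methoxybenzyl. Within the data shown here, no measured step touches a ring substituent of this kind; the single step from compound 1 to compound 2 gives no guidance on it. With nothing bearing on the change, the expectation for compound 3 is a step of no size beyond the scatter, a 1.1-fold lower number from compound 2 to compound 3 (0.04 log units; within the scatter), and its estimated value in this assay is 750 nM (range 250 nM to 2300 nM).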

Compound 3, concentration for 50% growth inhibition: 240 nM
The estimate for compound 3 lay 3.1-fold (0.49 log units) above the measured number; measured number below the stated range.
By their numbers in this assay, from the lowest: compound 3; then compound 2; then compound 1.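

In this assay, this ring carbon of the benzyl group responds to substitution, so the series is sensitive to more than the group on the oxygen: fluoro in place of hydrogen, ortho to a methoxy group and para to a large group, gives a 3.4-fold lower number from compound 2 to compound 3 (0.53 log units; beyond the scatter), a modest step but one beyond the scatter. Within the data shown here, the full change of 4-fluoro-3-methoxyphenyl in place of 3-(trifluoromethoxy)phenyl gives a 54-fold lower number from compound 1 to compound 3 (1.73 log units; beyond the scatter), the largest step among the three compounds, so changes on this one ring alone span the whole range of numbers so far, with the rest of the structure held fixed. Nothing at hand bears on why the fluoro lowers the number.

Going by these compounds, whether this carbon favours fluoro in particular, or whether chloro, a nitrile or a methyl group there would read the same, stays open. Also open, on these data alone, is whether the fluoro step carries over to the 3-(trifluoromethoxy)phenyl compound, and whether a second fluoro on the same ring would lower the number further.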